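Series notes: urea-to-amide step on the shared core

The compounds below may be only part of what the source reports. "The series", "measured", "known", "first", "only" and "open" are said of these compounds alone.

Three measured members share one core. Compound 1 `O=C(Nc1cccc(-n2cc(-c3ccncc3)c(-c3cc(O)cc(Cl)c3)n2)c1)Nc1ccc(Cl)c(C(F)(F)F)c1` gives 97% in a functional assay on U-251 cells (Homo sapiens) for inhibition, read by sulforhodamine B assay, with a stated time of 48 h, tested at 0.01 uM; on this read-out higher numbers stand for a weaker effect at the one concentration tested and lower numbers for a stronger effect. Compound 2 `O=C(Nc1cccc(-n2cc(-c3ccncc3)c(-c3cc(O)cc(Cl)c3)n2)c1)Nc1ccc(Cl)c(Cl)c1` gives 96%, with a number 1 percentage points lower from compound 1 to compound 2 (within the scatter). Compound 3 `COc1cc(Cl)cc(-c2nn(-c3cccc(NC(=O)Nc4ccc(Cl)c(Cl)c4)c3)cc2-c2ccncc2)c1` gives 95%, with a number 1 percentage points lower from compound 2 to compound 3 (within the scatter); compound 3 thus holds the lowest of the three numbers, though all three sit within the scatter of one another.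

Compound 4 `COc1cc(Cl)cc(-c2nn(-c3cccc(NC(=O)c4cccc(C(F)(F)F)c4)c3)cc2-c2ccncc2)c1` is not yet measured. It differs from compound 3 by 3-(trifluoromethyl)phenyl in place of (3,4-dichlorophenyl)amino on a carbonyl carbon. Neither measured step touches this part of the molecule: both were small and concerned the far ring and the phenol oxygen. Among the measured compounds shown here, no step therefore bears directly on it, and the expectation is a step of a number 3 percentage points lower from compound 3 to compound 4 (within the scatter), not beyond the scatter but with wide uncertainty. Compound 4 is estimated at 92%, between 72% and 100%.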

Compound 4, a percentage reported as activity, at one concentration (the size of the read-out at that concentration, not a potency): 94%
Beside the measured number, compound 4's estimate is 2 percentage points below it; the range from low to high includes it.
By their numbers in this assay, from the lowest: compounds 4, 3, 2 and 1 (each within the scatter of the next).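

The exchange of (3,4-dichlorophenyl)amino for 3-(trifluoromethyl)phenyl on a carbonyl carbon gives a number 1 percentage points lower from compound 3 to compound 4 (within the scatter) in this assay and is the first change shown at this position. The group that enters carries no hydrogen-bond donor, and the whole aryl portion changes, yet the step stays within the scatter. Nothing available accounts for this result.

On these data alone, whether any group on this carbonyl carbon can move the number beyond the scatter remains open. A piperidine amine or a longer alkyl chain there would test this.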